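The compounds below may be only part of what the source reports. "The series", "measured", "known", "first", "only" and "open" are said of these compounds alone.

Measured compounds in a functional assay on MCF7 cells (Homo sapiens) for antiproliferative activity, read by MTT assay, with a stated time of 72 h; on this read-out higher numbers stand for weaker inhibition and lower numbers for stronger inhibition:

Compound 1, `COc1nc(CC(O)(CO)CO)c(C)c(OC)n1`. In this assay compound 1 gives > 100000 nM, a limit of the assay rather than a number.

Compound 2, `CC(=O)OCC(O)(COC(C)=O)Cc1c(C)c(=O)[nH]c(=O)n1C`. In this assay compound 2 gives > 100000 nM, again a limit of the assay and not a number.

Among the compounds with values here, compound 2 thus stands at the upper end of what the assay reports; both values shown in this assay sit at the limit of > 100000 nM in this assay, at which 2 of the 2 values shown sit, so no measured step exists and no ordering between compound 1 and compound 2 can be drawn from them.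

Compound 3, `CC(=O)OCC(F)(COC(C)=O)Cc1c(C)c(=O)[nH]c(=O)n1C`, is not yet measured. It differs from compound 2 by fluoro in place of hydroxy on a saturated chain carbon bound to three saturated chain carbons. The shared core and the two acetyl esters are unchanged.

Within the data shown here, with compound 2 at the limit and no measured step to build on, no step beyond the scatter is expected in either direction; the estimated step that the limit leaves unreadable from compound 2 to compound 3 is taken as flat. Compound 3 is therefore expected to give about 150000 nM, with a range of 40000 nM to 600000 nM, and most likely the assay will again report only a limit for compound 3.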

Compound 3, half-maximal inhibitory concentration: > 100000 nM
Compound 3: a limit, no number; the forecaster's own chance of this, stated with the estimate: 80%; the middle value lies beyond the limit too.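

In this assay compound 3 gives > 100000 nM, a limit and not a number. The step from compound 2 to compound 3, fluoro in place of hydroxy, cannot be read, and no size can be given for it: the limit of > 100000 nM in this assay, at which 3 of the 3 values shown sit. The compounds shown leave open whether any change to this series gives a measurable value in this assay.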